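Swapping chloro for methyl on the shared core

The source may report more compounds than this note shows. Statements on the series, on what has been measured and on what is new or still open speak of the compounds shown alone.

Compound 3 `Cn1cnc(C(=O)NNC(=O)COc2c(F)cc(C(=O)c3ccc(Cl)cc3)cc2Cl)c1` gives 536000 nM in a functional assay on HeLa cells (Homo sapiens) for cytotoxicity, read by MTT assay, with a stated time of 48 h (a higher number here means a weaker inhibitor, a lower number a stronger inhibitor), the highest of the three numbers measured. For the measured compounds named here, its nearest neighbour, compound 2 `Cn1cnc(C(=O)NNC(=O)COc2c(F)cc(C(=O)c3ccc(F)cc3)cc2Cl)c1`, gives 42200 nM in this assay, and the only single-point step measured, a 13-fold higher number from compound 2 to compound 3 (1.10 log units; beyond the scatter), was chloro in place of fluoro on an aromatic carbon. Going by the values given here, compound 1 `Cc1ccc(C(=O)c2cc(F)c(OCC(=O)NNC(=O)c3ccc(=O)oc3)c(Cl)c2)cc1` gives 20900 nM, but it differs from compound 3 in two places, so no single step is drawn. Compound 4 `Cc1ccc(C(=O)c2cc(F)c(OCC(=O)NNC(=O)c3cn(C)cn3)c(Cl)c2)cc1` differs from compound 3 by methyl in place of chloro on an aromatic carbon. Among the compounds with values here, no measured step covers this exact change; since compound 1, which carries the same methyl, sits far lower, compound 4 is expected to give a lower number, estimated at 50000 nM (range 15000 nM to 200000 nM), a step of an 11-fold lower number from compound 3 to compound 4 (1.03 log units; beyond the scatter).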

Compound 4, half-maximal inhibitory concentration: 9900 nM
For compound 4 the middle estimate is 5.1-fold (0.70 log units) above the measured one; the measured number lies below the stated range.
By their numbers in this assay, from the lowest: compound 4; then compound 1; then compound 2; then compound 3.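

In this assay this place on the 4-methylphenyl ring matters more than the fluoro-to-chloro step alone could show: methyl gives the lowest number of the three groups here, with a large step against chloro (a 54-fold lower number from compound 3 to compound 4 (1.73 log units; beyond the scatter)) and a modest one against fluoro (a 4.3-fold lower number from compound 2 to compound 4 (0.63 log units; beyond the scatter)). With methyl held fixed, changing the ring group on the carbonyl carbon gives only a modest step (a 2.1-fold lower number from compound 1 to compound 4 (0.32 log units; beyond the scatter)). No measurement here explains any of these steps. From the compounds shown here alone, whether a methoxy group or an ethyl group at this place would give a still lower number remains open.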